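A few compounds are considered here, and "the series" means these few. Any claim that something is new, unique, unknown or untested is made for them only; others in the source may bear on it.

Three compounds share one core and differ only in the group that sits on the outer benzene ring. Compound 1 `O=C(CCCCCCc1ccccc1)c1ncc(-c2ccc([N+](=O)[O-])cc2)o1` carries a nitro group, and in an assay (Rattus norvegicus) for inhibition of Fatty-acid amide hydrolase 1 (Homo sapiens) (on this read-out higher numbers stand for weaker inhibition and lower numbers for stronger inhibition), compound 1 gives 50 nM. Compound 2 `COC(=O)c1ccc(-c2cnc(C(=O)CCCCCCc3ccccc3)o2)cc1` carries a methoxycarbonyl group instead, and in this assay compound 2 gives 40 nM. Compound 3 `O=C(CCCCCCc1ccccc1)c1ncc(-c2ccc(F)cc2)o1` carries a fluoro group, and in this assay compound 3 gives 62 nM. These three numbers lie close together: the swap from nitro to methoxycarbonyl gives a 1.3-fold lower number from compound 1 to compound 2 (0.10 log units; within the scatter), the swap from nitro to fluoro gives a 1.2-fold higher number from compound 1 to compound 3 (0.09 log units; within the scatter), and the swap from methoxycarbonyl to fluoro gives a 1.6-fold higher number from compound 2 to compound 3 (0.19 log units; within the scatter). Compound 3 therefore sits at the top of a narrow band, but it is separated from compounds 1 and 2 only within the scatter.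

Compound 4 `NS(=O)(=O)c1ccc(-c2cnc(C(=O)CCCCCCc3ccccc3)o2)cc1` is the next member. Relative to compound 3 the change is sulfamoyl in place of fluoro on an aromatic carbon. All three measured steps are swaps of the group at this same position, and none of them moved the number beyond the scatter. On that basis, a step within the scatter is expected in this assay, of roughly a 1.1-fold lower number from compound 3 to compound 4 (0.05 log units; within the scatter). Among the compounds with values here, compound 4 is estimated at 55 nM, most likely between 18 nM and 170 nM, since no measured compound carries a hydrogen-bond donor at this position and the estimate is correspondingly uncertain.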

Compound 4, inhibition constant: 10 nM
Estimate against measurement, compound 4: 5.5-fold (0.74 log units) above, and the stated range ends above it.
By their numbers in this assay, from the lowest: compound 4; then compounds 2, 1 and 3 (each within the scatter of the next).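

In this assay, the group on the outer benzene ring can matter after all: sulfamoyl stands apart from fluoro (a 6.2-fold lower number from compound 3 to compound 4 (0.79 log units; beyond the scatter)), from methoxycarbonyl (a 4.0-fold lower number from compound 2 to compound 4 (0.60 log units; beyond the scatter)) and from nitro (a 5.0-fold lower number from compound 1 to compound 4 (0.70 log units; beyond the scatter)), which makes compound 4 the strongest inhibitor of the four, whereas swaps among the other three groups stayed within the scatter. Sulfamoyl is also the only one of these four groups that brings a hydrogen-bond donor, but with a single such compound, that feature cannot be separated from the group's other differences, such as its larger size compared with fluoro. Nothing available here accounts for the stronger inhibition.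

The compounds shown leave open which part of the sulfamoyl group matters, a question that a methylsulfonyl group, with no nitrogen, and an N-methylsulfamoyl group, with one fewer hydrogen on that nitrogen, could help to answer. They also leave open whether a primary carboxamide or a carboxylic acid at this same position would give a similar result, or whether sulfamoyl is a special case.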